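Shortening the amide substituent to a propyl chain

The source may report more compounds than this note shows. Statements on the series, on what has been measured and on what is new or still open speak of the compounds shown alone.

Two compounds share a core in which the amide nitrogen carries a branched chain. In an ADME assay on HEK293 cells for agonist activity at metabotropic glutamate receptor 5 (Rattus norvegicus), read by fluorescence and calcium flux (a lower number here means a smaller maximal response, a higher number a larger maximal response), compound 1 `C[C@H](NC(=O)c1ccc(C#Cc2cccc(F)c2)cn1)C(C)(C)C` gives 20%, and compound 2 `CC(C)[C@H](C)NC(=O)c1ccc(C#Cc2cccc(F)c2)cn1` gives 13.1%; the step of a number 6.9 percentage points lower from compound 1 to compound 2 (within the scatter) lies within the scatter, so the two stand together rather than apart. Compound 3 `CCCNC(=O)c1ccc(C#Cc2cccc(F)c2)cn1` differs from compound 2 by propyl in place of 1,2-dimethylpropyl on an amide-type nitrogen. For the measured compounds named here, the only measured step touches the same chain and was within the scatter, so for compound 3 the expected step is a number 1.1 percentage points lower from compound 2 to compound 3 (within the scatter), no more than the scatter, and compound 3 is estimated at 12% with a range from 3% to 25%.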

Compound 3, largest response reached (reported as efficacy), in percent of the reference or control that the assay uses: 8.3%
Estimate against measurement, compound 3: 3.7 percentage points above, within the range that was stated.
By their numbers in this assay, from the lowest: compounds 3, 2 and 1 (each within the scatter of the next, the first and the last beyond it).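

In this assay, for the compounds shown here, propyl on the amide-type nitrogen gives a number 4.8 percentage points lower from compound 2 to compound 3 (within the scatter) and a number 11.7 percentage points lower from compound 1 to compound 3 (beyond the scatter), the first step at this position to pass the scatter. The position therefore shows a modest response, but only between the two ends of the series, since compound 2 stands within the scatter of both others. No evidence here accounts for this step.

A straight butyl chain or a cyclohexyl ring on the same nitrogen would help separate chain length from branching. On these data alone, a chain ending in an amine remains open as well.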